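Amide variation in a nitro-substituted benzyloxy aniline series

The source may hold more compounds than are shown below. What is called first, only, known or untested is meant among the compounds shown, and "the series" means these compounds.

Measured so far:
compound 1, `CS(=O)(=O)Nc1ccc([N+](=O)[O-])cc1OCc1ccc([N+](=O)[O-])cc1`: 400 nM
compound 2, `CC(=O)Nc1ccc([N+](=O)[O-])cc1OCc1ccccc1`: 1180 nM

Both compounds were tested in an assay on SK-BR-3 cells for inhibition of Aromatase (Homo sapiens); on this read-out higher numbers stand for weaker inhibition and lower numbers for stronger inhibition. Compound 2 stands at the higher of the two numbers; compound 1 gives the lower one, and the gap between them lies beyond the usual scatter. The two structures differ in more than one place, so nothing is attributed to any single change here.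

Compound 3, `N#Cc1ccc(C(=O)Nc2ccc([N+](=O)[O-])cc2OCc2ccccc2)cc1`, is not yet measured. It differs from compound 2 by 4-cyanophenyl in place of methyl on a carbonyl carbon. Among the compounds with values here, no measured pair shows this change, so the size of the step is open. A modest move toward a lower number is expected, close to the edge of the scatter, so that the step from compound 2 to compound 3 is estimated as a 2.0-fold lower number from compound 2 to compound 3 (0.29 log units; within the scatter). In this assay compound 3 is expected at 600 nM, with a range from 150 nM to 2500 nM.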

Compound 3, half-maximal inhibitory concentration: > 25000 nM
Compound 3 ended at the assay's limit; the forecaster's own chance of this, stated with the estimate: 5%; middle value at least 41-fold (1.61 log units) from the limit.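

In this assay compound 3 gives > 25000 nM, a limit of the assay and not a number. Placing 4-cyanophenyl in place of methyl on a carbonyl carbon gives an at least 21-fold higher number from compound 2 to compound 3 (1.32 log units; beyond the scatter), the first change in the series that can be read at a single place, and it shows that activity at this position depends strongly on what the carbonyl carbon carries. For compound 3 the step is a bound and not a measured size: the limit of > 25000 nM in this assay, at which 1 of the 3 values shown sits.

Going by these compounds, whether the step follows from the ring or from the nitrile stays open; phenyl without the nitrile, or a longer chain such as propyl, on the same carbonyl carbon would separate the two. The compounds shown also leave open whether the same change would give a similar step on the core of compound 1.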